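Moving a Methoxy on the Amide-Bound Phenyl

The compounds below may be only part of what the source reports. "The series", "measured", "known", "first", "only" and "open" are said of these compounds alone.

Compound 1 `COc1ccc(N2C(=O)COc3ccc(-c4cnc(OC)c(NS(=O)(=O)c5ccc(F)cc5)c4)cc32)cc1` gives 13400 nM.
Compound 2 `COc1ccc(N2C(=O)COc3ccc(-c4cnc(Cl)c(NS(=O)(=O)c5ccc(F)cc5)c4)cc32)cc1` gives 30100 nM.

In a functional assay on HCT-116 cells (Homo sapiens) for antiproliferative activity, read by MTT assay, with a stated time of 72 h (a higher number here means a weaker inhibitor, a lower number a stronger inhibitor), compound 1 stands at the lowest number of the two; the step of a 2.2-fold higher number from compound 1 to compound 2 (0.35 log units; beyond the scatter) separates it from compound 2. Compound 3 `COc1cccc(N2C(=O)COc3ccc(-c4cnc(OC)c(NS(=O)(=O)c5ccc(F)cc5)c4)cc32)c1` differs from compound 1 by 3-methoxyphenyl in place of 4-methoxyphenyl on an amide-type nitrogen in a ring. Within the data shown here, the only measured step concerns a different place, chloro in place of methoxy on an aromatic carbon, so no measured step bears on this change. Compound 3 is therefore expected to show no step beyond the scatter, no change at the digits printed from compound 1 to compound 3 (within the scatter). Compound 3 is estimated at 13400 nM, in a range from 5000 nM to 36000 nM.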

Compound 3, half-maximal inhibitory concentration: > 40000 nM
Compound 3: a limit, no number; the forecaster's own chance of this, stated with the estimate: 5%; middle value at least 2.9-fold (0.47 log units) away from the limit.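

In this assay compound 3 gives > 40000 nM, a limit of the assay and not a number. Among these compounds, with 3-methoxyphenyl in place of 4-methoxyphenyl on the amide-type nitrogen in a ring, the result is an at least 2.9-fold higher number from compound 1 to compound 3 (0.47 log units; beyond the scatter), so the place of the methoxy on this phenyl matters, which the earlier compounds could not show. The true size of this step stays unknown: the limit of > 40000 nM in this assay, at which 1 of the 3 values shown sits.

The compounds shown leave open how an amine or a carboxylic acid in place of the methoxy on this phenyl would read. They also leave open whether chloro in place of methoxy on the aromatic carbon would give a similar step with 3-methoxyphenyl present.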